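Swapping the Side Chain for an Aminopiperidinyl Sulfonyl Group

This account rests on a few compounds, and the source may have more. Where it says the series, first, only, none or still open, it means among the compounds named here.

Measured in an ADME assay on microsomes from liver (Homo sapiens) for metabolic stability, read by LC-MS, tested at 1 uM; on this read-out higher numbers stand for fast clearance and lower numbers for slow clearance:
- compound 1 `c1cc([C@H]2CC[C@]3(CC2)OOC2(O3)C3CC4CC(C3)CC2C4)ccc1OCCOC1CCNCC1`: < 7 mL.min-1.g-1 (a limit, not a number)
- compound 2 `CC(C)(O)CN1CCC(Oc2ccc([C@H]3CC[C@]4(CC3)OOC3(O4)C4CC5CC(C4)CC3C5)cc2)CC1`: 18 mL.min-1.g-1
- compound 3 `CC(C)(N)CCOc1ccc([C@H]2CC[C@]3(CC2)OOC2(O3)C3CC4CC(C3)CC2C4)cc1`: < 7 mL.min-1.g-1 (a limit, not a number)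

Compound 3 stands at the limit of < 7 mL.min-1.g-1 in this assay, at which 2 of the 3 values shown sit. Compound 4 `NC1CCN(S(=O)(=O)c2ccc([C@H]3CC[C@]4(CC3)OOC3(O4)C4CC5CC(C4)CC3C5)cc2)CC1` keeps the shared core but carries (4-aminopiperidin-1-yl)sulfonyl in place of 3-amino-3-methylbutoxy on an aromatic carbon, para to a large group ((4-aminopiperidin-1-yl)sulfonyl in place of 3-amino-3-methylbutoxy on an aromatic carbon).

Going by the values given here, no measured step introduces a sulfonyl group, so the guidance is indirect. Changes at this same oxygen-linked side chain gave an at least 2.5-fold higher number from compound 1 to compound 2 (0.41 log units; beyond the scatter) and then an at least 2.5-fold lower number from compound 2 to compound 3 (0.41 log units; beyond the scatter), so such swaps have moved the number modestly, in both directions. The remaining step, a step that the two limits leave unreadable from compound 1 to compound 3, adds nothing readable.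

Among the compounds with values here, compound 2, the only measured compound with a real number, reads 18 mL.min-1.g-1, so a modest rise at most is expected here. In this assay compound 4 may again give only a limit. The estimated change is an at least 1.1-fold higher number from compound 3 to compound 4 (0.05 log units; that floor lies within the scatter). Compound 4 is expected at 8 mL.min-1.g-1. The estimated range for compound 4 runs from 4 mL.min-1.g-1 to 22 mL.min-1.g-1.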

Compound 4, intrinsic clearance in microsomes: < 7 mL.min-1.g-1
Compound 4: only a limit was reported (the forecaster's own chance of this, stated with the estimate: 50%); middle value at least 1.1-fold (0.05 log units) away from the limit.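

The (4-aminopiperidin-1-yl)sulfonyl group is the first side chain here that is attached to the aromatic carbon through a sulfonyl group rather than an oxygen, and in this assay compound 4 still gives only a limit: the limit of < 7 mL.min-1.g-1 in this assay, at which 3 of the 4 values shown sit.

Going by these compounds alone, the one readable comparison is an at least 2.5-fold lower number from compound 2 to compound 4 (0.41 log units; beyond the scatter), so an oxygen link is not required for a reading at this limit. The steps that join two limits cannot be read.

On these data alone, how far each limited compound really lies under the limit stays unknown, so the sulfonyl side chain cannot be ranked against the oxygen-linked side chains of compound 1 and compound 3. Also open, as far as these compounds go, is how a sulfonyl-linked piperidine with a hydroxyl group in place of the amine would read in this assay.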